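The source may hold more compounds than are shown below. What is called first, only, known or untested is meant among the compounds shown, and "the series" means these compounds.

In a functional assay on MGC-803 cells (Homo sapiens) for antiproliferative activity, read by MTT assay, with a stated time of 48 h (a lower number here means a stronger inhibitor, a higher number a weaker inhibitor), the series reads as follows

- compound 1 `COc1ccc(CN(C(=O)CSc2nc3ccccc3s2)c2cc(OC)c(OC)c(OC)c2)cc1` gives 163 nM
- compound 2 `COc1ccc(CN(C(=O)CSc2nc3ccccc3s2)c2cc(OC)c(OC)c(OC)c2)cc1O` gives 35 nM
- compound 3 `COc1cc(N(Cc2ccc(Cl)cc2)C(=O)CSc2nc3ccccc3s2)cc(OC)c1OC` gives > 80000 nM

Among the measured compounds shown here, compound 3 stands at > 80000 nM as its only reading, and that is a limit of the assay and not a number.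

Compound 4 `COc1ccc(CN(C(=O)CSc2nc3ccccc3s2)c2cc(OC)c(OC)c(OC)c2)cc1C(F)(F)F` is not yet measured. The change from compound 3 is 4-methoxy-3-(trifluoromethyl)phenyl in place of 4-chlorophenyl on a saturated chain carbon bound to an amide-type nitrogen.

The closest measured step is an at least 490-fold higher number from compound 1 to compound 3 (2.69 log units; beyond the scatter), a large one for chloro in place of methoxy on an aromatic carbon, and compound 4 carries the methoxy again. The step of an at least 2200-fold higher number from compound 2 to compound 3 (3.35 log units; beyond the scatter) is also large. The step of a 4.7-fold lower number from compound 1 to compound 2 (0.67 log units; beyond the scatter) is modest and shows one case where hydroxy in place of hydrogen on an aromatic carbon costs nothing. For the measured compounds named here, no measured compound carries trifluoromethyl, so that part of the change remains open and the range stays wide.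

A large step towards a lower number is therefore expected in this assay, with compound 1 at 163 nM as the nearest anchor. The expected step is an at least 130-fold lower number from compound 3 to compound 4 (2.12 log units; beyond the scatter).

For compound 4 the estimate is 600 nM, with an expected range from 80 nM to 10000 nM.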

Compound 4, half-maximal inhibitory concentration: 25200 nM
Compound 4: the middle estimate sits 42-fold (1.62 log units) below what was measured; measured number above the stated range.
By their numbers in this assay, from the lowest: compound 2; then compound 1; then compound 4. At a limit, above all of these: compound 3.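

In this assay the aromatic carbon where hydroxy replaced hydrogen also accepts trifluoromethyl, but the number moves the other way: trifluoromethyl in place of hydrogen gives a 150-fold higher number from compound 1 to compound 4 (2.19 log units; beyond the scatter), and trifluoromethyl in place of hydroxy gives a 720-fold higher number from compound 2 to compound 4 (2.86 log units; beyond the scatter). This carbon therefore moves the number in both directions, and the methoxy group alone does not keep the series at the level of the two hydrogen and hydroxy compounds, as compound 4 carries methoxy and still reads far higher than either. Setting 4-methoxy-3-(trifluoromethyl)phenyl in place of 4-chlorophenyl gives an at least 3.1-fold lower number from compound 3 to compound 4 (0.50 log units; beyond the scatter), a step bounded on one side only, and its true size cannot be read from a limit: the limit of > 80000 nM in this assay, at which 1 of the 4 values shown sits.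

The compounds shown leave open whether fluoro, methyl or an amine on that same aromatic carbon would read closer to compound 2 or closer to compound 4. They also leave open where a carboxylic acid at that carbon would fall, and whether the gain from hydroxy survives once the methoxy group is replaced by an ethoxy group.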